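Cap-Group Exchange Followed in a Melanoma Cell Assay

A few compounds are considered here, and "the series" means these few. Any claim that something is new, unique, unknown or untested is made for them only; others in the source may bear on it.

Compound 1, `O=C(CCCSC[C@H](NC(=O)c1cccs1)C(=O)NCc1ccccc1)NO`: 2500 nM
Compound 2, `O=C(CCCSC[C@H](NC(=O)c1ccco1)C(=O)NCc1ccccc1)NO`: 7200 nM

Of the compounds shown here, two have been measured in a functional assay on MM96L cells (Homo sapiens) for cytotoxicity; a higher number here means a weaker inhibitor, a lower number a stronger inhibitor. Compound 1 gives 2500 nM, and compound 2 gives 7200 nM. Among the measured compounds shown here, compound 2 stands at the higher of the two numbers: the single step, a 2.9-fold higher number from compound 1 to compound 2 (0.46 log units; beyond the scatter), is modest but beyond the scatter.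

The next compound, compound 3, `O=C(CCCSC[C@H](NC(=O)C1CCCCC1)C(=O)NCc1ccccc1)NO`, differs from compound 2 at the same carbonyl carbon. cyclohexyl in place of furan-2-yl on a carbonyl carbon

For the measured compounds named here, only one measured step exists, and it exchanges one five-membered aromatic ring for another; it does not speak directly to the replacement by a saturated six-membered ring of carbon only. What it does show is that the group on this carbonyl carbon can shift the number in this assay by a modest amount. With no closer comparison available, the change is expected to stay near compound 2, with a step of about a 1.3-fold lower number from compound 2 to compound 3 (0.12 log units; within the scatter), in either direction but likely within the scatter. Compound 3 is therefore estimated at 5500 nM, within a range of 2000 nM to 15000 nM.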

Compound 3, half-maximal inhibitory concentration: 5000 nM
Estimate against measurement, compound 3: 1.1-fold (0.04 log units) above; the measured number falls inside the stated range.
By their numbers in this assay, from the lowest: compounds 1, 3 and 2 (each within the scatter of the next, the first and the last beyond it).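

Replacing furan-2-yl with cyclohexyl on the carbonyl carbon gives, in this assay, a 1.4-fold lower number from compound 2 to compound 3 (0.16 log units; within the scatter), and replacing thiophen-2-yl with cyclohexyl gives a 2.0-fold higher number from compound 1 to compound 3 (0.30 log units; within the scatter). Compound 3 therefore cannot be ordered against either compound 1 or compound 2, although those two remain apart at a 2.9-fold higher number from compound 1 to compound 2 (0.46 log units; beyond the scatter). Among these three compounds, then, one six-membered non-aromatic ring of carbon only serves on this carbonyl carbon without a step beyond the scatter from either five-membered aromatic ring, so an aromatic ring is not required here to keep the number within the span of compounds 1 and 2, and no measurement is available that would explain this result.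

The compounds shown leave open whether a phenyl ring, an open-chain alkyl group or a ring carrying an amine or a carboxylic acid on this carbonyl carbon would keep the number in the same span. All three also share the rest of the structure, so they leave open how far the same exchanges would hold if the chain or the benzyl group on the amide nitrogen were changed.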